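Two Sulfonyl Aryl Variants at the Assay Ceiling

The compounds below may be only part of what the source reports. "The series", "measured", "known", "first", "only" and "open" are said of these compounds alone.

The compounds share one core, a quinolinone carrying methoxy groups and a sulfonyl-bound aryl group on the ring nitrogen. Compound 1 `COc1ccc(-c2c(Br)c(=O)c3c(OC)cc(OC)cc3n2S(=O)(=O)c2ccc(OC)cc2)cc1` was examined in a functional assay on HepG2 cells (Homo sapiens) for antiproliferative activity, with a stated time of 72 h; on this read-out higher numbers stand for an effect only at larger amounts of compound and lower numbers for an effect already at smaller amounts. For compound 1 the result is a limit of the assay rather than a number, > 20000 nM. Compound 2 `COc1ccc(-c2cc(=O)c3c(OC)cc(OC)cc3n2S(=O)(=O)c2ccc([N+](=O)[O-])cc2)cc1` differs from it in the sulfonyl aryl group and in the absence of the bromine. For compound 2 the result is likewise a limit, > 29300 nM, so that compound 2 stands at the limit of > 29300 nM in this assay, at which 1 of the 2 values shown sits, and the other value shown is also a limit, (the limit of > 20000 nM in this assay, at which 1 of the 2 values shown sits). Within the data shown here, no step between two measured compounds can therefore be given.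

Compound 3 `COc1ccc(-c2cc(=O)c3c(OC)cc(OC)cc3n2S(=O)(=O)c2ccc(C)c([N+](=O)[O-])c2)cc1` is the unmeasured compound. It differs from compound 2 by 4-methyl-3-nitrophenyl in place of 4-nitrophenyl on a sulfonyl sulfur. Among the measured compounds shown here, with both measured compounds sitting at a limit, there is no measured step on which a direction could rest, and no effect beyond the usual scatter is expected. The expected step that the limit leaves unreadable from compound 2 to compound 3 is accordingly none. Compound 3 is expected to give about 30000 nM, with a range from 8000 nM to 120000 nM, most likely reported again only as a limit.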

Compound 3, half-maximal effective concentration: > 51700 nM
Compound 3 ended at the assay's limit (the forecaster's own chance of this, stated with the estimate: 75%); at least 1.7-fold (0.23 log units) between middle value and limit.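

Among these compounds, compound 2 and compound 3 each gave only a limit rather than a number in this assay, so no step between them can be read. The compounds shown leave open whether 4-methyl-3-nitrophenyl in place of 4-nitrophenyl on a sulfonyl sulfur changes the read-out at all, and at what concentration any of them would show an effect.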